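Amide-capped long-chain series: working notes on cytotoxicity

A few compounds are considered here, and "the series" means these few. Any claim that something is new, unique, unknown or untested is made for them only; others in the source may bear on it.

Compound 1 `CCCCCCCCCCCCCCCCCCNC(=O)[C@@H](N)[C@@H](C)O`: 27400 nM in a functional assay on MCF7 cells (Homo sapiens) for cytotoxicity, read by MTT assay, with a stated time of 48 h; a lower number here means a stronger inhibitor, a higher number a weaker inhibitor
Compound 2 `CCCCCCCCCCCCCCCCCCNC(=O)[C@@H](NC(=O)c1ccco1)[C@@H](C)O`: 21400 nM in this assay
Compound 3 `CCCCCCCCCCCCCCCCCCNC(=O)[C@@H](NC(=O)c1nccc2ccccc12)[C@@H](C)O`: 30800 nM in this assay

Compound 3 carries the highest of the three numbers, yet both steps to it lie within the scatter: a 1.1-fold higher number from compound 1 to compound 3 (0.05 log units; within the scatter) and a 1.4-fold higher number from compound 2 to compound 3 (0.16 log units; within the scatter). Compound 4 `CCCCCCCCCCCCCCCCCCNC(=O)[C@@H](NC(=O)/C=C/c1ccccc1)[C@@H](C)O` differs from compound 3 by 2-phenylethenyl in place of isoquinolin-1-yl on a carbonyl carbon. Going by the values given here, no measured step exchanges one acyl substituent for this one; the steps that bear on the acyl position are a 1.3-fold lower number from compound 1 to compound 2 (0.11 log units; within the scatter), a 1.1-fold higher number from compound 1 to compound 3 (0.05 log units; within the scatter) and a 1.4-fold higher number from compound 2 to compound 3 (0.16 log units; within the scatter), each within the scatter, so changes at this position have so far moved nothing. In this assay a step of about a 1.2-fold lower number from compound 3 to compound 4 (0.09 log units; within the scatter) is therefore expected, none beyond the scatter. Compound 4 is estimated at 25000 nM, with a range of 10000 nM to 60000 nM.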

Compound 4, half-maximal inhibitory concentration: 39200 nM
The estimate for compound 4 lay 1.6-fold (0.20 log units) below the measured number; the range from low to high includes it.
By their numbers in this assay, from the lowest: compounds 2, 1, 3 and 4 (each within the scatter of the next).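

Placing 2-phenylethenyl on the carbonyl carbon instead of isoquinolin-1-yl swaps two aromatic rings for one plus a double bond outside it, and the number in this assay stays within the scatter (a 1.3-fold higher number from compound 3 to compound 4 (0.10 log units; within the scatter)). Going by these compounds alone, the largest step so far at this position (a 1.8-fold higher number from compound 2 to compound 4 (0.26 log units; within the scatter)) and the step from the uncapped amine (a 1.4-fold higher number from compound 1 to compound 4 (0.16 log units; within the scatter)) are also within the scatter, so three different acyl groups have moved nothing. No measurement on hand accounts for this flat response.

As far as these compounds go, it remains open whether the octadecyl chain, not the acyl group, sets the number; a shorter chain, or an acyl group carrying a carboxylic acid or an amine, would test this.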